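Working notes: chloro to tert-butyl step in a cytotoxicity series

The source may hold more compounds than are shown below. What is called first, only, known or untested is meant among the compounds shown, and "the series" means these compounds.

Measured compounds:
Compound 1 `CCN(CC)Cc1ccc2nc(NC(=O)N/N=C/c3cn(Cc4ccc(C(C)(C)C)cc4)c4ccccc34)sc2c1` — 1670 nM
Compound 2 `CCN(CC)Cc1ccc2nc(NC(=O)N/N=C/c3cn(Cc4ccc(Cl)cc4)c4ccccc34)sc2c1` — 370 nM
Compound 3 `CC1CCN(Cc2ccc3nc(NC(=O)N/N=C/c4cn(Cc5ccc(Cl)cc5)c5ccccc45)sc3c2)CC1` — 400 nM

All three were run in a functional assay on NCI-H460 cells (Homo sapiens) for cytotoxicity, read by MTT assay, with a stated time of 72 h; on this read-out lower numbers stand for stronger inhibition and higher numbers for weaker inhibition. Compound 2 gives 370 nM and compound 3 gives 400 nM; these two differ by 4-methylpiperidin-1-yl in place of diethylamino on a saturated chain carbon bound to an aromatic carbon, and the step of a 1.1-fold higher number from compound 2 to compound 3 (0.03 log units; within the scatter) shows that this change in the core leaves the read-out essentially where it was. Going by the values given here, compound 1 gives 1670 nM; it differs from compound 2 by tert-butyl in place of chloro on an aromatic carbon, and the step of a 4.5-fold higher number from compound 2 to compound 1 (0.65 log units; beyond the scatter) is the only change in the set that moves the number clearly.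

Compound 4 `CC1CCN(Cc2ccc3nc(NC(=O)N/N=C/c4cn(Cc5ccc(C(C)(C)C)cc5)c5ccccc45)sc3c2)CC1` is not yet measured. It differs from compound 3 by tert-butyl in place of chloro on an aromatic carbon. The place line for this change reads word for word as it does for the change from compound 2 to compound 1, so it is the same change, applied on the core of compound 3 instead of the core of compound 2; the two cores differ by 4-methylpiperidin-1-yl in place of diethylamino on a saturated chain carbon bound to an aromatic carbon, which on its own made no step beyond the scatter.

Since compound 3 and compound 2 sit within the scatter of each other, and the chloro to tert-butyl change has been seen once, the expectation is that compound 4 repeats it: a step of about a 4.5-fold higher number from compound 3 to compound 4 (0.65 log units; beyond the scatter) is expected, resting on a 4.5-fold higher number from compound 2 to compound 1 (0.65 log units; beyond the scatter). Compound 4 is therefore estimated at 1800 nM in this assay, with a range from 800 nM to 4000 nM. With one prior example only, the range is kept wide.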

Compound 4, half-maximal inhibitory concentration: 3370 nM
Compound 4: the middle estimate sits 1.9-fold (0.27 log units) below what was measured; low and high end bracket the measured number.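

In this assay the chloro to tert-butyl change carries over to the second core, with an 8.4-fold higher number from compound 3 to compound 4 (0.93 log units; beyond the scatter), and its size there does not separate from the earlier step: the same change on two cores in this assay, a 4.5-fold higher number (0.65 log units; beyond the scatter) from compound 2 to compound 1 and an 8.4-fold higher number (0.93 log units; beyond the scatter) from compound 3 to compound 4, 1.9-fold (0.27 log units) apart, within the scatter of two such steps. The amine change holds up in the same way on the tert-butyl pair, with a 2.0-fold higher number from compound 1 to compound 4 (0.30 log units; within the scatter), which agrees with what the chloro pair showed: the same change on two cores in this assay, a 1.1-fold higher number (0.03 log units; within the scatter) from compound 2 to compound 3 and a 2.0-fold higher number (0.30 log units; within the scatter) from compound 1 to compound 4, 1.9-fold (0.27 log units) apart, within the scatter of two such steps. Going by these compounds alone, this supports treating the two changes as independent of each other across these four compounds, but it rests on only two cores that differ solely in the amine, so it neither shows a real core dependence in the size of the tert-butyl step nor shows that the step would carry to a core changed elsewhere, and it gives no reason for the step.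

The compounds shown leave open how other groups on that aromatic carbon would read, such as fluoro, methoxy, trifluoromethyl or a plain hydrogen, since chloro and tert-butyl are the only two points there. They also leave open whether other amines on the saturated chain carbon, such as morpholine or an N-methylpiperazine, would stay as close to diethylamino as 4-methylpiperidin-1-yl does.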